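Ethylsulfamoyl in Place of Isopropylsulfonyl on a Shared Core

The compounds below may be only part of what the source reports. "The series", "measured", "known", "first", "only" and "open" are said of these compounds alone.

Compound 1, `CC(C)c1noc(N2CCN(C(=O)[C@@H]3CCCN(S(=O)(=O)c4ccc(S(=O)(=O)NC5CC5)cc4)C3)CC2)n1`: 300 nM in a functional assay on MIA PaCa-2 cells (Homo sapiens) for inhibition, read by MTT assay, with a stated time of 3 days; a higher number here means a weaker inhibitor, a lower number a stronger inhibitor.
Compound 2, `CCN(CC)C(=O)c1ccc(S(=O)(=O)N2CCC[C@@H](C(=O)N3CCN(c4nc(C(C)C)no4)CC3)C2)cc1`: 70 nM in this assay.
Compound 3, `CC(C)c1noc(N2CCN(C(=O)[C@@H]3CCCN(S(=O)(=O)c4ccc(S(=O)(=O)C(C)C)cc4)C3)CC2)n1`: 30 nM in this assay.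

Compound 3 gives the lowest number of the three, with the steps of a 2.3-fold lower number from compound 2 to compound 3 (0.37 log units; beyond the scatter) and a 10-fold lower number from compound 1 to compound 3 (1.00 log units; beyond the scatter) both beyond the scatter. Compound 4, `CCNS(=O)(=O)c1ccc(S(=O)(=O)N2CCC[C@@H](C(=O)N3CCN(c4nc(C(C)C)no4)CC3)C2)cc1`, differs from compound 3 by ethylamino in place of isopropyl on a sulfonyl sulfur. The step that bears most on this change is a 10-fold lower number from compound 1 to compound 3 (1.00 log units; beyond the scatter), where the amino-bearing sulfonyl gave the higher number; compound 4 returns to a sulfamoyl, so a move back toward compound 1 is expected, though the smaller ethylamino group leaves the size uncertain. The expected step is a 5.0-fold higher number from compound 3 to compound 4 (0.70 log units; beyond the scatter). Compound 4 is therefore estimated at 150 nM in this assay, within a range of 50 nM to 450 nM.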

Compound 4, half-maximal inhibitory concentration: 200 nM
Compound 4: the middle estimate sits 1.3-fold (0.12 log units) below what was measured, and the stated range covers the measured number.
By their numbers in this assay, from the lowest: compound 3; then compound 2; then compounds 4 and 1 (each within the scatter of the next).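

In this assay the sulfonyl sulfur proves sensitive to what it carries even when the heavy-atom count stays at 3: ethylamino in place of isopropyl gives a 6.7-fold higher number from compound 3 to compound 4 (0.82 log units; beyond the scatter), so the earlier gap does not depend on the cyclopropyl ring. Ethylsulfamoyl also falls behind diethylcarbamoyl, with a 2.9-fold higher number from compound 2 to compound 4 (0.46 log units; beyond the scatter). Ethyl in place of cyclopropyl on the sulfonamide nitrogen gives only a 1.5-fold lower number from compound 1 to compound 4 (0.18 log units; within the scatter), which leaves these two sulfamoyl compounds inseparable.

Nothing given here explains these steps. On these data alone, whether methyl or dimethylamino on the sulfonyl sulfur would side with isopropyl or with the sulfamoyl groups remains open.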